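This account rests on a few compounds, and the source may have more. Where it says the series, first, only, none or still open, it means among the compounds named here.

In a functional assay on HCT-15 cells (Homo sapiens) for antiproliferative activity, read by MTT assay, with a stated time of 72 h (on this read-out higher numbers stand for weaker inhibition and lower numbers for stronger inhibition), the compounds are judged by how strongly they hold back the growth of colon cancer cells. Compound 1 `CCCCn1ccnc1-c1cc(OC)c(OC)c(OC)c1` carries a butyl chain on a ring nitrogen of its shared core. Compound 1 gives only a limit of the assay, > 100000 nM. Compound 2 `CCCCCn1ccnc1-c1cc(OC)c(OC)c(OC)c1` carries a pentyl chain in the same place. Compound 2 likewise gives only a limit, > 100000 nM. The step that the two limits leave unreadable from compound 1 to compound 2 therefore cannot be read, since both values sit at the limit (the limit of > 100000 nM in this assay, at which 2 of the 2 values shown sit).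

Compound 3 `COc1cc(-c2nccn2-c2ccc(F)cc2)cc(OC)c1OC` differs from compound 2 by 4-fluorophenyl in place of pentyl on an aromatic nitrogen. Among the measured compounds shown here, no measured step touches a change from a chain to an aromatic ring, so the one measured step offers no guide on size or direction. For compound 3 the estimate is 20000 nM, lying between 1000 nM and 100000 nM, which as a step from compound 2 is expected to be an at least 5.0-fold lower number from compound 2 to compound 3 (0.69 log units; beyond the scatter).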

Compound 3, half-maximal inhibitory concentration: 68600 nM
Estimate against measurement, compound 3: 3.4-fold (0.54 log units) below; the measured number falls inside the stated range.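

Among the compounds shown here, on an aromatic nitrogen of the shared core, 4-fluorophenyl gives the only reading in this assay that is a number and not a limit, so a change at this position can bring a compound within the range the assay can read. Replacing pentyl with this ring is an at least 1.4-fold lower number from compound 2 to compound 3 (0.16 log units; that floor lies within the scatter), and replacing butyl with it is an at least 1.4-fold lower number from compound 1 to compound 3 (0.16 log units; that floor lies within the scatter). Both sizes are only floors, and the true gaps may be larger, because the two chain compounds give limits and not numbers: the limit of > 100000 nM in this assay, at which 2 of the 3 values shown sit.

The compounds shown do not separate the effect of the ring from that of its fluorine, which a plain phenyl group would help to do. They also leave open whether a longer chain, or a chain ending in an amine, would give a readable number at this position.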